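The source may report more compounds than this note shows. Statements on the series, on what has been measured and on what is new or still open speak of the compounds shown alone.

Measured so far:
compound 1 `NS(=O)(=O)c1ccc(C(=O)N/N=C(/CS(=O)(=O)c2ccccc2)c2ccccc2)cc1`, 10700 nM
compound 2 `NS(=O)(=O)c1ccc(C(=O)N/N=C(/CS(=O)(=O)c2ccccc2)c2ccc(Br)cc2)cc1`, 19100 nM
compound 3 `NS(=O)(=O)c1ccc(N/N=C(/CS(=O)(=O)c2ccccc2)c2ccccc2)cc1`, 3970 nM

In a functional assay on MCF7 cells (Homo sapiens) for antiproliferative activity, read by MTT assay (on this read-out lower numbers stand for stronger inhibition and higher numbers for weaker inhibition), compound 1 gives 10700 nM and compound 2 gives 19100 nM. Compound 3 gives 3970 nM, the lowest of the three numbers; its nearest neighbour is compound 1, and the gap to compound 2 is wider. The difference between the core of compound 1 and the core of compound 3 is not broken down here. Compound 2 differs from compound 1 by bromo in place of hydrogen on an aromatic carbon; this step is a 1.8-fold higher number from compound 1 to compound 2 (0.25 log units; within the scatter). Compound 4 `NS(=O)(=O)c1ccc(N/N=C(/CS(=O)(=O)c2ccccc2)c2ccc(Br)cc2)cc1` is not yet measured; it differs from compound 3 by bromo in place of hydrogen on an aromatic carbon, the same change at the same place. The step from compound 3 to compound 4 is expected to be a 1.5-fold higher number from compound 3 to compound 4 (0.18 log units; within the scatter), because the same change gave a 1.8-fold higher number from compound 1 to compound 2 (0.25 log units; within the scatter). For compound 4 the expected value is 6000 nM, estimated to lie between 2500 nM and 14000 nM.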

Compound 4, half-maximal inhibitory concentration: 17300 nM
The estimate for compound 4 lay 2.9-fold (0.46 log units) below the measured number, outside the stated range (above it).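

In this assay, the change from phenyl to 4-bromophenyl gives a 4.4-fold higher number from compound 3 to compound 4 (0.64 log units; beyond the scatter). This step lies beyond the scatter and the earlier step on the core of compound 1 lies within it, yet the two cannot be told apart: the same change on two cores in this assay, a 1.8-fold higher number (0.25 log units; within the scatter) from compound 1 to compound 2 and a 4.4-fold higher number (0.64 log units; beyond the scatter) from compound 3 to compound 4, 2.4-fold (0.39 log units) apart, within the scatter of two such steps. The change therefore carries over between these two cores as far as the data can resolve, but one pair of steps does not show that its size is fixed or that it would hold on a further core.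

From the compounds shown here alone, whether chloro, methoxy or an amine in place of the bromo would behave alike remains open. So does the effect of a carboxylic acid in place of the sulfonamide on either core.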